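Swapping phenyl for phenoxy on an anti-inflammatory pyridazinone

The source may hold more compounds than are shown below. What is called first, only, known or untested is meant among the compounds shown, and "the series" means these compounds.

Measured compounds:
Compound 1, `COc1ccc(C2=NN(c3ccc(S(C)(=O)=O)cc3)C(=O)CC2)cc1`: in a functional assay on the whole organism (strain Wistar) for inhibition, with Rattus norvegicus as the target, read by paw edema, with stated times of 30 min and 5 h, at a dose of 0.05 mmol/kg by the oral route (on this read-out higher numbers stand for more inhibition at the one dose given (going by the name of the read-out) and lower numbers for less inhibition), compound 1 gives 68.4%.
Compound 2, `CS(=O)(=O)c1ccc(N2N=C(c3ccccc3)CCC2=O)cc1`: in this assay compound 2 gives 47.3%.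
Compound 3, `CS(=O)(=O)c1ccc(N2N=C(c3ccc(-c4ccccc4)cc3)CCC2=O)cc1`: in this assay compound 3 gives 21%.

Compound 3 stands lowest of the three: its step from compound 2 is a number 26.3 percentage points lower from compound 2 to compound 3 (beyond the scatter), and the gap from compound 1 is a number 47.4 percentage points lower from compound 1 to compound 3 (beyond the scatter), both beyond the scatter. Compound 4, `CS(=O)(=O)c1ccc(N2N=C(c3ccc(Oc4ccccc4)cc3)CCC2=O)cc1`, differs from compound 3 at one place: phenoxy in place of phenyl on an aromatic carbon.

Among the measured compounds shown here, no measured step exchanges phenyl for phenoxy, so the nearest guides are indirect. The step of a number 21.1 percentage points lower from compound 1 to compound 2 (beyond the scatter) shows that removing an oxygen-bearing methoxy lowered inhibition, while a number 26.3 percentage points lower from compound 2 to compound 3 (beyond the scatter) shows that adding a phenyl lowered it further. Compound 4 keeps a large group at that place but brings back an oxygen, so a small rise from compound 3 is expected, within or only slightly beyond the scatter, as a number 9 percentage points higher from compound 3 to compound 4 (within the scatter). Compound 4 is therefore estimated at 30%, with a likely range from 10% to 55%.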

Compound 4, a percentage reported as inhibition, in the whole organism at one dose (the size of the read-out at that dose, not a potency): 65.7%
Estimate against measurement, compound 4: 35.7 percentage points below; the measured number lies above the stated range.
By their numbers in this assay, from the lowest: compound 3; then compound 2; then compounds 4 and 1 (each within the scatter of the next).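

In this assay a second aromatic ring at this place does not by itself go with low inhibition: phenoxy in place of phenyl gives a number 44.7 percentage points higher from compound 3 to compound 4 (beyond the scatter) from a change that adds only an oxygen link. Set against the hydrogen, phenoxy gives a number 18.4 percentage points higher from compound 2 to compound 4 (beyond the scatter) while phenyl went the opposite way, so the link decides the direction of the step in these compounds. Phenyl in place of methyl on the oxygen gives a number 2.7 percentage points lower from compound 1 to compound 4 (within the scatter) and so leaves methoxy and phenoxy level at this place.

Nothing measured here explains why the oxygen link matters so much. On these data alone, whether a sulfur atom, an amine nitrogen or a methylene link would serve like the oxygen remains open, as does the effect of a substituent on the outer phenyl ring.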